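Working notes: compound 2 to compound 4 in this series

The source may hold more compounds than are shown below. What is called first, only, known or untested is meant among the compounds shown, and "the series" means these compounds.

The series shares one core; compounds differ in the group on the nitrogen-bound phenyl and at the second position of the core. Compound 1 `COc1ccc(N(C)c2nc(C)nc3c2CCC3)cc1` carries a methoxy on that phenyl and a methyl on the core; in a functional assay on MDA-MB-435 cells (Homo sapiens) for inhibition, read by sulforhodamine B assay, with a stated time of 48 h (a lower number here means a stronger inhibitor, a higher number a weaker inhibitor), compound 1 gives 7 nM. Compound 3 `COc1ccccc1N(C)c1nc(N)nc2c1CCC2` carries a methoxy and an amino group. In this assay compound 3 gives only a limit, > 1000 nM. Compound 2 `CN(c1ccc(Cl)cc1)c1ncnc2c1CCC2` carries a chloro; in this assay compound 2 has "not determined" (no result reported), so it has no number of its own to stand on. Among the measured compounds shown here, the only further value shown is the limit reached by compound 3, (the limit of > 1000 nM in this assay, at which 1 of the 3 values shown sits). For the measured compounds named here, no step between two measured compounds can be drawn here.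

Compound 4 `CSc1ccc(N(C)c2ncnc3c2CCC3)cc1` differs from compound 2 as follows: methylsulfanyl in place of chloro on an aromatic carbon. The group enters on an aromatic carbon of a six-membered aromatic ring of carbon only, para to a large group. Going by the values given here, with no measured step to lean on, the size and direction of the change in this assay cannot be set from the data; only an expectation remains. Compound 4 is estimated at 60 nM, expected to fall between 8 nM and 500 nM.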

Compound 4, half-maximal inhibitory concentration: 42.8 nM
Estimate against measurement, compound 4: 1.4-fold (0.15 log units) above, and the stated range covers the measured number.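

In this assay compound 4 gives 42.8 nM but compound 2 has no number of its own, so no new step can be read between them. The compounds shown leave open how methylsulfanyl and chloro compare at this place on the shared core's phenyl. No information shown bears on the value of compound 4.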